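The compounds below may be only part of what the source reports. "The series", "measured", "known", "first", "only" and "open" are said of these compounds alone.

Compound 2 `CCO/N=C/Nc1cc(Cl)c(SSCC)c(Cl)c1` gives 5 in a physicochemical assay for lipophilicity, measured as octanol-water partition (on this read-out higher numbers stand for higher lipophilicity and lower numbers for lower lipophilicity), the second highest of the three numbers recorded. Compound 1 `CCCCc1c(Cl)cc(N/C=N/OCC)cc1Cl` gives 5.6, and compound 3 `C=CCOc1c(Cl)cc(N/C=N/OCC)cc1Cl` gives 4.3. The path from compound 2 to compound 4 `CCO/N=C/Nc1cc(Cl)c(OCCCl)c(Cl)c1` changes one place on the shared core: 2-chloroethoxy in place of (ethylsulfanyl)sulfanyl on an aromatic carbon. Of the measured steps, the one that bears most directly on this change is a number 0.70 log units lower from compound 2 to compound 3 (beyond the scatter), where an oxygen-linked chain likewise took the place of the same (ethylsulfanyl)sulfanyl group on the same aromatic carbon. The further steps a number 0.60 log units lower from compound 1 to compound 2 (beyond the scatter) and a number 1.30 log units lower from compound 1 to compound 3 (beyond the scatter) set the wider span of the series. Because a number 0.70 log units lower from compound 2 to compound 3 (beyond the scatter) was a modest fall, a fall of similar size is expected on moving to the 2-chloroethoxy compound, that is a number 0.60 log units lower from compound 2 to compound 4 (beyond the scatter) as an estimate. Compound 4 is therefore expected to give about 4.4, within a range from 3.9 to 4.9.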

Compound 4, partition coefficient: 4
The estimate for compound 4 lay 0.40 log units above the measured number, within the range that was stated.
By their numbers in this assay, from the lowest: compounds 4 and 3 (each within the scatter of the next); then compound 2; then compound 1.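

In this assay the 2-chloroethoxy group in place of (ethylsulfanyl)sulfanyl gives a number 1.00 log units lower from compound 2 to compound 4 (beyond the scatter) and so a second oxygen-linked chain now stands beyond the scatter from the sulfur-linked group, where earlier only allyloxy had shown this. The two oxygen-linked chains cannot be told apart, with a number 0.30 log units lower from compound 3 to compound 4 (within the scatter) so chloromethyl in place of vinyl on the saturated chain carbon bound to the oxygen makes no readable difference here. Set against butyl, the 2-chloroethoxy group gives a number 1.60 log units lower from compound 1 to compound 4 (beyond the scatter) and this is the widest step among the four compounds.

No measured evidence is at hand that accounts for these steps. Still open, going by these compounds, is how an amine or a carboxylic acid on this aromatic carbon, or a longer chain on the oxygen, would read against these four numbers.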